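Hydrogen in Place of Acetyl on a Bromothiophene Ester

The source may hold more compounds than are shown below. What is called first, only, known or untested is meant among the compounds shown, and "the series" means these compounds.

Compound 1, `CC(=O)Oc1cccc2cc(-c3ccsc3)c(=O)oc12`: in an assay on CHO cells for displacement of a labelled ligand from adenosine receptor A1 (Homo sapiens) (a higher number here means a weaker inhibitor, a lower number a stronger inhibitor), compound 1 reaches only the assay limit, > 100000 nM.
Compound 2, `CC(=O)Oc1cccc2cc(-c3cc(Br)cs3)c(=O)oc12`: in this assay compound 2 likewise stops at the limit, > 100000 nM.
Compound 3, `CC(=O)Oc1ccc2cc(-c3cc(Br)cs3)c(=O)oc2c1OC(C)=O`: in this assay compound 3 also gives no more than the limit, > 100000 nM.

Compound 2 therefore stands at the limit, and so does every other measured compound, as the limit of > 100000 nM in this assay, at which 3 of the 3 values shown sit, records. The step from compound 2 to compound 4, `O=c1oc2c(O)cccc2cc1-c1cc(Br)cs1`, is hydrogen in place of acetyl on an oxygen on an aromatic ring. Among the measured compounds shown here, two measured steps touch compound 2. The change a step that the two limits leave unreadable from compound 1 to compound 2 and the change a step that the two limits leave unreadable from compound 2 to compound 3 both run between limits, so neither gives a readable size, and the second of them concerns acetoxy entering on an aromatic carbon, a different position from the oxygen altered here. For the measured compounds named here, no measured step thus tells how large the move to compound 4 should be. With all three values at the limit, compound 4 is expected to show a step of an at least 1.2-fold lower number from compound 2 to compound 4 (0.09 log units; that floor lies within the scatter) in this assay, most likely none that a limit can reveal. Compound 4 is accordingly estimated at 80000 nM, within 10000 nM to 300000 nM.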

Compound 4, inhibition constant: > 100000 nM
Compound 4: no number, only a limit; the forecaster's own chance of this, stated with the estimate: 80%; middle value at least 1.2-fold (0.09 log units) away from the limit.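

In this assay compound 4 gives > 100000 nM, a limit and not a number. Compound 2 also stands at a limit, so no step can be read between compound 2 and compound 4. The compounds shown leave open how strong an inhibitor any of them is.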